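Removing the Bromine from the Shared Core

A few compounds are considered here, and "the series" means these few. Any claim that something is new, unique, unknown or untested is made for them only; others in the source may bear on it.

Compound 3 `O=c1oc2cc(Br)cnc2n1CCN1CCN(c2ccccc2)CC1` is measured in a functional assay on the whole organism with Mus musculus as the target; on this read-out higher numbers stand for an effect only at larger amounts of compound and lower numbers for an effect already at smaller amounts; in this assay compound 3 gives 34.1 mg/kg. Compound 1 `O=c1oc2cccnc2n1CCN1CCN(c2ccc(F)cc2)CC1` gives 41.3 mg/kg, which lies within the scatter of the value for compound 3. For compound 2 `CN1CCN(CCn2c(=O)oc3cccnc32)CC1` the read-out gives only a limit, > 25 mg/kg. Among the compounds with values here, the single step between measured compounds that differ in one place, a step that the limit leaves unreadable from compound 1 to compound 2, cannot be read because of the limit of > 25 mg/kg in this assay, at which 1 of the 3 values shown sits. Compound 4 `O=c1oc2cccnc2n1CCN1CCN(c2ccccc2)CC1` differs from compound 3 by hydrogen in place of bromo on an aromatic carbon. No measured step touches this position, so nothing shown sets the size of this change. Compound 4 is therefore expected to give 38 mg/kg, in a range from 18 mg/kg to 80 mg/kg. The expected step of a 1.1-fold higher number from compound 3 to compound 4 (0.05 log units; within the scatter) is no change beyond the scatter.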

Compound 4, dose for half-maximal effect: 19.4 mg/kg
Beside the measured number, compound 4's estimate is 2.0-fold (0.29 log units) above it; the range from low to high includes it.
By their numbers in this assay, from the lowest: compounds 4, 3 and 1 (each within the scatter of the next, the first and the last beyond it).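

In this assay, within the data shown here, hydrogen in place of bromo on this aromatic carbon gives a 1.8-fold lower number from compound 3 to compound 4 (0.24 log units; within the scatter), the first measured step at this position, so the effect does not depend on the bromo. Hydrogen in place of fluoro gives a 2.1-fold lower number from compound 1 to compound 4 (0.33 log units; beyond the scatter), the only step here beyond the scatter, while phenyl in place of methyl on the ring amine nitrogen gives an at least 1.2-fold lower number from compound 2 to compound 4 (0.11 log units; that floor lies within the scatter). Compound 2 gives only a limit, so that last step is a floor: the limit of > 25 mg/kg in this assay, at which 1 of the 4 values shown sits.

As far as these compounds go, what a chloro, a methoxy or an amine on this aromatic carbon would give stays open.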